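The compounds below may be only part of what the source reports. "The series", "measured", "known", "first", "only" and "open" are said of these compounds alone.

Measured compounds and their values:

- compound 1, `Cc1nn(-c2ccccc2I)c2c1C(c1ccc(Oc3ccccc3)cc1)SC(C)C(=O)N2`: 1300 nM
- compound 2, `COc1ccccc1-c1ccc([C@H]2S[C@@H](C)C(=O)Nc3c2c(C)nn3-c2ccccc2C)cc1`: 1100 nM
- compound 3, `COc1cc([C@H]2S[C@@H](C)C(=O)Nc3c2c(C)nn3-c2ccccc2C)ccc1Oc1ccccc1`: 1900 nM

All three were tested in an assay on isolated protein for agonist activity at Bile acid receptor (Homo sapiens), read by AlphaScreen, with a stated time of 30 min; on this read-out higher numbers stand for an effect only at larger amounts of compound and lower numbers for an effect already at smaller amounts. Compound 2 has the lowest of the three numbers, but its nearest neighbour, compound 1, sits within the scatter of repeated measurements, and so does the furthest, compound 3. On these numbers the three compounds cannot be told apart, and compound 2 is not to be called the most active of them.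

Compound 4, `Cc1ccccc1-n1nc(C)c2c1NC(=O)[C@H](C)S[C@@H]2c1ccc(-c2ccccc2)cc1`, is the next compound and has not yet been measured. It differs from compound 2 in one place: hydrogen in place of methoxy on an aromatic carbon. Within the data shown here, no pair of measured compounds shows this particular change, so there is no direct precedent for its effect. With the three measured compounds all sitting within the scatter of one another despite differences at the same end of the molecule, the expectation is a step of about the size of the scatter, in no particular direction. The step from compound 2 to compound 4 is therefore estimated at a 1.3-fold higher number from compound 2 to compound 4 (0.10 log units; within the scatter). For compound 4 in this assay the estimate is 1400 nM, with a range from 500 nM to 4000 nM.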

Compound 4, half-maximal effective concentration: 990 nM
Compound 4: middle estimate off by 1.4-fold (0.15 log units), on the high side; the measured number falls inside the stated range.
By their numbers in this assay, from the lowest: compounds 4, 2, 1 and 3 (each within the scatter of the next).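

Replacing the methoxy of the 2-methoxyphenyl group with hydrogen, which leaves plain phenyl, gives a 1.1-fold lower number from compound 2 to compound 4 (0.05 log units; within the scatter) in this assay. Among these compounds, this is the first direct comparison at this position, and it shows that the methoxy group, with its two heavy atoms and one hydrogen-bond acceptor, can be removed from this aromatic carbon, ortho to a large group, without a change that stands out from the scatter of repeated measurements. No accompanying measurement bears on this result.

From the compounds shown here alone, what remains open is whether a different group at this place, such as an amine, a carboxylic acid or a longer chain such as butoxy, would move the number beyond the scatter. Going by these compounds, it is also open whether hydrogen in place of methoxy would give a similarly small step at other positions on this ring.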